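Aryl Swaps on a Triazole Nitrogen in a Spiro Series

The source may report more compounds than this note shows. Statements on the series, on what has been measured and on what is new or still open speak of the compounds shown alone.

Compound 1 `CC(=O)Nc1ccc(-n2nncc2CN2C(=O)C3(C(C#N)=C(N)Oc4c3c3nc5ccccc5nc3c3ccccc43)c3ccccc32)cc1` in a functional assay on HCT-116 cells (Homo sapiens) for antiproliferative activity, read by MTT assay, with a stated time of 48 h (on this read-out lower numbers stand for stronger inhibition and higher numbers for weaker inhibition), reaches only the limit > 50000 nM.
Compound 2 `N#CC1=C(N)Oc2c(c3nc4ccccc4nc3c3ccccc23)C12C(=O)N(Cc1cnnn1-c1cccc(S(N)(=O)=O)c1)c1ccccc12` in this assay gives 11300 nM.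
Compound 3 `Cc1ccc(-n2nncc2CN2C(=O)C3(C(C#N)=C(N)Oc4c3c3nc5ccccc5nc3c3ccccc43)c3ccccc32)c(C)c1` in this assay reaches only the limit > 50000 nM.

Compound 3 thus sits at the limit, together with compound 1, as the limit of > 50000 nM in this assay, at which 2 of the 3 values shown sit, records. Compound 4 `N#CC1=C(N)Oc2c(c3nc4ccccc4nc3c3ccccc23)C12C(=O)N(Cc1cnnn1-c1ccc(F)c(Cl)c1)c1ccccc12` differs from compound 3 by 3-chloro-4-fluorophenyl in place of 2,4-dimethylphenyl on an aromatic nitrogen. Among the compounds with values here, the step of an at least 4.4-fold higher number from compound 2 to compound 3 (0.64 log units; beyond the scatter) shows that the 3-sulfamoylphenyl is the one aryl group here paired with a numerical value, while a step that the two limits leave unreadable from compound 1 to compound 3 cannot be read. The entering 3-chloro-4-fluorophenyl shares with the leaving group its lack of hydrogen-bond donors and acceptors, so compound 4 is expected to stay near the limit, an at least 1.2-fold lower number from compound 3 to compound 4 (0.09 log units; that floor lies within the scatter). Compound 4 is therefore estimated at 40000 nM in this assay, within 10000 nM to 100000 nM.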

Compound 4, half-maximal inhibitory concentration: > 50000 nM
Compound 4 gave a limit, no number; the forecaster's own chance of this, stated with the estimate: 60%; at least 1.2-fold (0.09 log units) between middle value and limit.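

With 3-chloro-4-fluorophenyl on the aromatic nitrogen, compound 4 also reaches only a limit, not a number: the limit of > 50000 nM in this assay, at which 3 of the 4 values shown sit. Within the data shown here, a chlorine- and fluorine-bearing aryl group therefore joins the acetamido and dimethyl cases, leaving the 3-sulfamoylphenyl of compound 2 as the only aryl group here with a numerical value, with an at least 4.4-fold higher number from compound 2 to compound 4 (0.64 log units; beyond the scatter). The steps among compounds 1, 3 and 4 cannot be read, as both ends of each are limits.

As far as these compounds go, whether the sulfamoyl group needs its printed ring position remains open. So does how an aryl group carrying an amine or a carboxylic acid would read in this assay.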